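A methoxy swap among compounds at a limit

The source may hold more compounds than are shown below. What is called first, only, known or untested is meant among the compounds shown, and "the series" means these compounds.

In an ADME assay on microsomes from liver (Rattus norvegicus) for metabolic stability (a higher number here means that the compound lasts longer, a lower number that the compound disappears faster), compound 1 (`Nc1nc(NCCNc2ncc(-c3ncc[nH]3)c(-c3ccc(C(F)(F)F)cc3)n2)ccc1[N+](=O)[O-]`) gives > 0.5 h as a limit, not a number. Compound 2 (`Nc1nc(NCCNc2ncc(-c3ncc[nH]3)c(-c3ccccc3Br)n2)ccc1[N+](=O)[O-]`) gives > 0.5 h as a limit too. Compound 3 (`Cc1cc(Cl)ccc1-c1nc(NCCNc2ccc([N+](=O)[O-])c(N)n2)ncc1-c1ncc[nH]1`) gives > 0.5 h as a limit as well. All three share the limit of > 0.5 h in this assay, at which 3 of the 3 values shown sit, and cannot be ranked.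

Compound 4 (`COc1cc(Cl)ccc1-c1nc(NCCNc2ccc([N+](=O)[O-])c(N)n2)ncc1-c1ncc[nH]1`) differs from compound 3 by methoxy in place of methyl on an aromatic carbon and is not yet measured. For the measured compounds named here, the steps that bear on this are a step that the two limits leave unreadable from compound 1 to compound 2 together with a step that the two limits leave unreadable from compound 1 to compound 3 and a step that the two limits leave unreadable from compound 2 to compound 3 and none offers a size to carry over. So a step that the limit leaves unreadable from compound 3 to compound 4 is expected in this assay with no direction foreseen. The expected half-life of compound 4 is 0.6 h with an estimated range from 0.35 h to 1.2 h. Compound 4 too is expected to give only a limit.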

Compound 4, half-life: > 0.5 h
Compound 4: a limit, no number (the forecaster's own chance of this, stated with the estimate: 75%); the middle value lies beyond the limit too.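

No step from compound 1, compound 2 or compound 3 to compound 4 can be read in this assay, because all four compounds stop at the same limit: the limit of > 0.5 h in this assay, at which 4 of the 4 values shown sit.

The compounds shown leave open how long each actually lasts, and so whether methoxy or methyl gives the longer half-life.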